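Removing a chloro group from a thiazole-linked pyrimidine

The source may report more compounds than this note shows. Statements on the series, on what has been measured and on what is new or still open speak of the compounds shown alone.

Three compounds share a thiazole ketone joined through a sulfur atom to a six-membered nitrogen heterocycle. Compound 1 `Cc1nc(-c2ccccc2)sc1C(=O)CSc1nc(-c2ccc(Cl)c(Cl)c2)c(C#N)c(=O)[nH]1` carries a 3,4-dichlorophenyl group on that heterocycle, compound 3 `Cc1nc(-c2ccccc2)sc1C(=O)CSc1nc(-c2cccc(Cl)c2)c(C#N)c(=O)[nH]1` a 3-chlorophenyl group, and compound 2 `Cc1nc(-c2ccccc2)sc1C(=O)CSc1nc(N)c(C#N)c(-c2ccc(Cl)cc2)n1` has a different core bearing an amino group and a 4-chlorophenyl group. The difference between the core of compound 2 and the core of compound 1 is not broken down here.

In a functional assay on U-87MG ATCC cells for antiproliferative activity against U-87 MG (Homo sapiens), read by MTT assay, with a stated time of 48 h, tested at 10 uM (a lower number here means a stronger effect, a higher number a weaker effect of the compound at the concentration tested), compound 1 gives 92.5%. In this assay compound 3 gives 83.7%. The change from compound 1 to compound 3 is hydrogen in place of chloro on an aromatic carbon, and it moved the number by a number 8.8 percentage points lower from compound 1 to compound 3 (within the scatter). In this assay compound 2 gives 58.8%, the lowest of the three and beyond the scatter from both others.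

Compound 4 `Cc1nc(-c2ccccc2)sc1C(=O)CSc1nc(N)c(C#N)c(-c2ccccc2)n1` is not yet measured. It arises from compound 2 by hydrogen in place of chloro on an aromatic carbon. This is the same kind of change as from compound 1 to compound 3, though there the leaving chloro stood ortho to a chloro group, whereas in compound 2 no second chloro is present. Given that the earlier step was a number 8.8 percentage points lower from compound 1 to compound 3 (within the scatter), a similarly small move is expected here, namely a number 2.8 percentage points lower from compound 2 to compound 4 (within the scatter). Compound 4 is therefore estimated to give 56% in this assay, likely between 42% and 72%.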

Compound 4, a percentage reported as activity, at one concentration (the size of the read-out at that concentration, not a potency): 93%
Beside the measured number, compound 4's estimate is 37 percentage points below it; measured number above the stated range.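

In this assay, replacing the chloro group with hydrogen on the core of compound 2, the change from 4-chlorophenyl to phenyl, gives a number 34.2 percentage points higher from compound 2 to compound 4 (beyond the scatter). Since a lower number means a stronger effect, the compound without the chloro group has a clearly weaker effect at the concentration tested, so the change does not carry over from one core to the other in this series: the same change on two cores in this assay, a number 8.8 percentage points lower (within the scatter) from compound 1 to compound 3 and a number 34.2 percentage points higher (beyond the scatter) from compound 2 to compound 4, 43 percentage points apart, beyond the scatter of two such steps

This shows that the result of removing a chloro group cannot simply be assumed to transfer between these cores, but it does not show why the two outcomes differ. Within the data shown here, each core offers only one pair, the chloro group leaves a different ring position in each pair, and the cores themselves differ, so these data cannot separate those factors or establish a general rule.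

Still open, on these data alone, is how other groups at the same place on the core of compound 2, such as a fluoro, bromo or methoxy group, would compare with chloro and hydrogen. Also open, as far as these compounds go, is whether the large step from the 4-chlorophenyl to the phenyl compound would appear at other concentrations or in other cell lines.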